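A few compounds are considered here, and "the series" means these few. Any claim that something is new, unique, unknown or untested is made for them only; others in the source may bear on it.

Among the compounds with values here, in a functional assay on HeLa cells (Homo sapiens) for inhibition, read by CCK-8 assay, with a stated time of 48 h (a lower number here means a stronger inhibitor, a higher number a weaker inhibitor), compound 1 (`COc1cc(-c2ccnc3cc(-c4ccc(C)cc4)nn23)cc(OC)c1OC`) gives 21 nM, the lower of the two numbers so far, while compound 2 (`COc1cc(-c2ccnc3cc(-c4ccc(C)c(C)c4)nn23)cc(OC)c1OC`) gives 241 nM. Compound 3 (`CCOC(=O)c1ccc(-c2cc3nccc(-c4cc(OC)c(OC)c(OC)c4)n3n2)cc1`) has ethoxycarbonyl in place of methyl on an aromatic carbon, para to a large group: ethoxycarbonyl in place of methyl on an aromatic carbon. Within the data shown here, only one measured step bears on this, and only indirectly: methyl in place of hydrogen on an aromatic carbon, which gave an 11-fold higher number from compound 1 to compound 2 (1.06 log units; beyond the scatter). A higher number of somewhat smaller size is therefore expected in this assay, though one step is thin support. For compound 3 the estimated value is 150 nM, within 35 nM to 700 nM. The expected step is a 7.1-fold higher number from compound 1 to compound 3 (0.85 log units; beyond the scatter).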

Compound 3, half-maximal inhibitory concentration: > 10000 nM
Compound 3 ended at the assay's limit; the forecaster's own chance of this, stated with the estimate: 5%; middle value at least 66-fold (1.82 log units) away from the limit.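

In this assay compound 3 gives > 10000 nM, which is a limit of the assay and not a number. The change of ethoxycarbonyl in place of methyl brings an at least 470-fold higher number from compound 1 to compound 3 (2.67 log units; beyond the scatter), so this aromatic carbon tolerates far less than the earlier pair could show. Compound 1 and compound 2 both gave measured numbers, while this single replacement carries the value to the limit. The compounds shown leave open where between methyl and ethoxycarbonyl the value falls away. On these data alone, how a carboxylic acid or an amine on this carbon would read in this assay also remains open.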